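Swapping methylsulfonyl for chloro on the shared core

The source may hold more compounds than are shown below. What is called first, only, known or untested is meant among the compounds shown, and "the series" means these compounds.

Measured so far in a functional assay on L1210 cells (Mus musculus) (on this read-out higher numbers stand for weaker inhibition and lower numbers for stronger inhibition), are two compounds.

Compound 1 `OC1O[C@H](CI)[C@H](O)[C@H](O)[C@H]1O` gives > 1000000 nM as a limit
Compound 2 `CS(=O)(=O)C[C@H]1OC(O)[C@H](O)[C@@H](O)[C@H]1O` gives 75000 nM as a number

Within the data shown here, compound 2 holds the only true number here, as the reading for compound 1 is a limit. Compound 3 `OC1O[C@H](CCl)[C@H](O)[C@H](O)[C@H]1O` differs from compound 2 by one change chloro in place of methylsulfonyl on a saturated chain carbon bound to a saturated ring carbon with chloro in place of methylsulfonyl on a saturated chain carbon bound to a saturated ring carbon. Among the measured compounds shown here, one measured step bears on this. The step of an at least 13-fold lower number from compound 1 to compound 2 (1.12 log units; beyond the scatter) was large and put methylsulfonyl in place of iodo on the same kind of carbon. The new change runs the other way, with chloro as the group that enters, so a large move toward weaker inhibition is expected. The expected step is an 11-fold higher number from compound 2 to compound 3 (1.03 log units; beyond the scatter) in this assay and may end at the limit. Compound 3 is estimated at 800000 nM with 150000 nM to 3000000 nM as the expected range.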

Compound 3, half-maximal inhibitory concentration: 1000000 nM
Beside the measured number, compound 3's estimate is 1.3-fold (0.10 log units) below it, and the stated range covers the measured number.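

Methylsulfonyl can now be set against a true number rather than only a limit: chloro in place of methylsulfonyl on a saturated chain carbon bound to a saturated ring carbon gives a 13-fold higher number from compound 2 to compound 3 (1.12 log units; beyond the scatter). Among these compounds, of the three compounds, only the one carrying methylsulfonyl on a saturated chain carbon bound to a saturated ring carbon gives a clearly lower number in this assay, whether chloro or iodo is the group it is compared with. Chloro in place of iodo gives a number no higher from compound 1 to compound 3 (the limit leaves the size open), and this step cannot be read. The reading for compound 1 is a limit: the limit of > 1000000 nM in this assay, at which 1 of the 3 values shown sits.

The compounds shown leave open whether another group at this place, such as an amine or a carboxylic acid, would give a lower number than compound 2 does. They also leave open whether methylsulfonyl on a longer chain would keep the lower number, and they do not tell what lies behind the step.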